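Carbamoyl to dimethylamino on the side chain: an untested step

This account rests on a few compounds, and the source may have more. Where it says the series, first, only, none or still open, it means among the compounds named here.

compound 1 `NC(=O)Cc1cc(=O)oc2cc(OCc3ccccc3)ccc12` — 8000 nM
compound 2 `NC(=O)Cc1cc(=O)oc2cc(OCc3cccc(F)c3)ccc12` — 70000 nM

Going by the values given here, in an assay (strain Wistar) for inhibition of Amine oxidase [flavin-containing] A (Rattus norvegicus) (on this read-out lower numbers stand for stronger inhibition and higher numbers for weaker inhibition), compound 1 gives 8000 nM, the lower of the two numbers so far, while compound 2 gives 70000 nM. Among the compounds with values here, the only measured step, an 8.8-fold higher number from compound 1 to compound 2 (0.94 log units; beyond the scatter), comes from fluoro in place of hydrogen on an aromatic carbon. Compound 3 `CN(C)Cc1cc(=O)oc2cc(OCc3ccccc3)ccc12` differs from compound 1 by dimethylamino in place of carbamoyl on a saturated chain carbon bound to an aromatic carbon. Within the data shown here, this is a different part of the molecule, so no measured step bears on it, and the direction is open. The expected step is a 1.3-fold higher number from compound 1 to compound 3 (0.10 log units; within the scatter), within the scatter. Compound 3 is therefore estimated at 10000 nM, ranging from 1500 nM to 60000 nM.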

Compound 3, half-maximal inhibitory concentration: 100000 nM
For compound 3 the middle estimate is 10-fold (1.00 log units) below the measured one; the measured number lies above the stated range.
By their numbers in this assay, from the lowest: compound 1; then compounds 2 and 3 (each within the scatter of the next).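

In this assay, replacing carbamoyl with dimethylamino on the saturated chain carbon gives a 13-fold higher number from compound 1 to compound 3 (1.10 log units; beyond the scatter), so the group at this place clearly affects inhibition. The change removes the hydrogen-bond donor counted for carbamoyl while keeping one hydrogen-bond acceptor, but nothing available links the weaker inhibition to that difference or to any other feature of the groups.

Still open, on these data alone, is whether a primary amine, a carboxylic acid or a longer amide chain at this place would give a lower number than compound 1. Also open, as far as these compounds go, is whether any other replacement would keep the inhibition seen with carbamoyl.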